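Solubility of a shared core carrying different aromatic groups

This account rests on a few compounds, and the source may have more. Where it says the series, first, only, none or still open, it means among the compounds named here.

Measured compounds:
- Compound 1, `COc1ccc(F)cc1CNCCCNc1ccnc2cc(CCC(C)C)ccc12`: 4200 nM
- Compound 2, `COc1ccc(F)cc1CNCCCNc1ccnc2cc(-c3ccccc3)ccc12`: 32000 nM
- Compound 3, `COc1ccc(F)cc1CNCCCNc1ccnc2cc(Oc3ccc(Cl)cc3)ccc12`: 14500 nM

All three share one core and differ only in the group placed on one aromatic carbon. In a physicochemical assay for solubility, with a stated time of 18 h, at pH 7.4 (on this read-out lower numbers stand for lower solubility and higher numbers for higher solubility), compound 3 stands second highest of the three numbers. Its nearest neighbour is compound 2, the step being a 2.2-fold lower number from compound 2 to compound 3 (0.34 log units; beyond the scatter); the furthest is compound 1, with a 3.5-fold higher number from compound 1 to compound 3 (0.54 log units; beyond the scatter). The remaining measured step, a 7.6-fold higher number from compound 1 to compound 2 (0.88 log units; beyond the scatter), also swaps the whole group on that carbon.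

Compound 4, `COc1ccc(F)cc1CNCCCNc1ccnc2cc(Oc3cccc(N(C)C)c3)ccc12`, has not yet been measured in this assay. Its change from compound 3 is 3-(dimethylamino)phenyl in place of 4-chlorophenyl on an oxygen on an aromatic ring. Here the group on the oxygen is exchanged, while the entering group is counted as bringing one hydrogen-bond acceptor where the leaving group had none.

Within the data shown here, none of the measured steps exchanges a substituent on the phenoxy ring, so they only show that group swaps on this core move solubility by modest amounts. I therefore expect a step of a 1.8-fold higher number from compound 3 to compound 4 (0.25 log units; within the scatter), upward and just beyond the scatter, but with little support. Compound 4 is estimated at 26000 nM, within 10000 nM to 65000 nM.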

Compound 4, solubility: 14500 nM
Compound 4: the middle estimate sits 1.8-fold (0.25 log units) above what was measured, and the stated range covers the measured number.
By their numbers in this assay, from the lowest: compound 1; then compounds 3 and 4 (each within the scatter of the next); then compound 2.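

In this assay, the exchange on the oxygen gives no change at the digits printed from compound 3 to compound 4 (within the scatter) when 3-(dimethylamino)phenyl replaces 4-chlorophenyl, so this first measured change within the phenoxy group leaves the number in place, even though the entering group is counted with one hydrogen-bond acceptor and the leaving group with none. Compound 4 therefore relates to the other two compounds just as compound 3 does, with a 2.2-fold lower number from compound 2 to compound 4 (0.34 log units; beyond the scatter) and with a 3.5-fold higher number from compound 1 to compound 4 (0.54 log units; beyond the scatter) as the steps that replace the whole group on the aromatic carbon, so all three such steps to a phenoxy group stay beyond the scatter while this exchange stays within it. No measurement shown here explains why the two substituted phenoxy groups give matching numbers.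

This single exchange removes the chlorine and adds the dimethylamino group at once, so the compounds shown leave open what each would do alone, a question that an unsubstituted phenoxy group could help to separate. They also leave open whether the number would hold with a carboxylic acid or a morpholine on the phenoxy ring.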